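This account rests on a few compounds, and the source may have more. Where it says the series, first, only, none or still open, it means among the compounds named here.

Of the compounds shown here, two carry numbers so far. In an ADME assay on L6 cells (Rattus norvegicus) for cytotoxicity (on this read-out higher numbers stand for weaker inhibition and lower numbers for stronger inhibition), compound 1 (`C/C=C(/C)C(=O)OC(C)c1cc2c(cc1OC)OC(C)(C)C=C2`) gives 139000 nM as its half-maximal inhibitory concentration, the higher of the two numbers and so the weaker inhibition of the pair. Compound 2 (`COc1cc2c(cc1C(C)N[C@H](C)c1ccccc1)C=CC(C)(C)O2`) gives 15900 nM on the same read-out, and the gap between them lies beyond the usual scatter. For the measured compounds named here, compound 1 therefore stands at the top of a very short range, and no single-site step between measured compounds is available for calibration. Compound 3 (`COc1cc2c(cc1C(C)N1CCCC1)C=CC(C)(C)O2`) has no number yet. It differs from compound 1 in one place, a saturated chain carbon bound to an aromatic carbon and a saturated chain carbon, where pyrrolidin-1-yl stands in place of ((1-methylprop-1-en-1-yl)carbonyl)oxy (pyrrolidin-1-yl in place of ((1-methylprop-1-en-1-yl)carbonyl)oxy on a saturated chain carbon bound to an aromatic carbon and a saturated chain carbon). With only compound 2 at 15900 nM as a guide to how low the numbers can go, a moderate downward move beyond the scatter is expected in this assay for this change. The estimated change is a 4.6-fold lower number from compound 1 to compound 3 (0.67 log units; beyond the scatter) in size, toward stronger inhibition. For compound 3 the expected value is 30000 nM within an estimated range of 10000 nM to 90000 nM on this read-out.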

Compound 3, half-maximal inhibitory concentration: 177000 nM
For compound 3 the middle estimate is 5.9-fold (0.77 log units) below the measured one, outside the stated range (above it).
By their numbers in this assay, from the lowest: compound 2; then compounds 1 and 3 (each within the scatter of the next).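

In this assay, pyrrolidin-1-yl in place of ((1-methylprop-1-en-1-yl)carbonyl)oxy on a saturated chain carbon bound to an aromatic carbon and a saturated chain carbon gives a 1.3-fold higher number from compound 1 to compound 3 (0.10 log units; within the scatter) and so leaves the two compounds unseparated on this read-out. This first single-site step shows that this position accepts a five-membered non-aromatic ring with a nitrogen in place of an open chain with two double bonds, without a change that the assay can resolve. A nitrogen-bearing group on this carbon is therefore not enough on its own to reach the level of compound 2 at 15900 nM in this series, since compound 3 carries one and stays level with compound 1. No measurement at hand bears on what lies behind this result.

As far as these compounds go, whether an open-chain diethylamino group or a benzylamino group on the same carbon would sit with compound 3 or with compound 2 remains open. Also open, from the compounds shown here alone, is whether the phenyl ring of compound 2 or its amine hydrogen goes with its lower number.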